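From pyridin-2-yl to pyridin-4-yl in compound 3

This account rests on a few compounds, and the source may have more. Where it says the series, first, only, none or still open, it means among the compounds named here.

In a functional assay on MIA PaCa-2 cells (Homo sapiens) for cytotoxicity, read by MTT assay, with a stated time of 72 h (a higher number here means a weaker inhibitor, a lower number a stronger inhibitor), compound 1 (`COC1=CC(=O)c2c(COc3ccc(F)cc3)c(C)n(C)c2C1=O`) gives 493 nM and compound 2 (`COC1=CC(=O)c2c(COc3ccccn3)c(C)n(C)c2C1=O`) gives 2390 nM as the higher of the two numbers. Going by the values given here, the one measured step, a 4.8-fold higher number from compound 1 to compound 2 (0.69 log units; beyond the scatter) with pyridin-2-yl in place of 4-fluorophenyl on an oxygen on a saturated carbon, is modest and beyond the scatter. Compound 3 (`COC1=CC(=O)c2c(COc3ccncc3)c(C)n(C)c2C1=O`) has not been measured and differs from compound 2 by pyridin-4-yl in place of pyridin-2-yl on an oxygen on a saturated carbon with the same atoms joined differently. Among the compounds with values here, the step of a 4.8-fold higher number from compound 1 to compound 2 (0.69 log units; beyond the scatter) is the only one bearing on this change, and it bears on it loosely. Within the data shown here, it replaces 4-fluorophenyl, and no measured step compares pyridin-4-yl with pyridin-2-yl. No step beyond the scatter is therefore expected in this assay in either direction. The step expected is a 1.2-fold lower number from compound 2 to compound 3 (0.08 log units; within the scatter) and no more. The estimate for compound 3 is 2000 nM (range 700 nM to 5500 nM).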

Compound 3, half-maximal inhibitory concentration: 3270 nM
Compound 3: middle estimate off by 1.6-fold (0.21 log units), on the low side; the range from low to high includes it.
By their numbers in this assay, from the lowest: compound 1; then compounds 2 and 3 (each within the scatter of the next).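

In this assay the exchange of pyridin-2-yl for pyridin-4-yl on an oxygen on a saturated carbon gives a 1.4-fold higher number from compound 2 to compound 3 (0.14 log units; within the scatter) and so does not separate the two groups. The exchange of 4-fluorophenyl for pyridin-4-yl gives a 6.6-fold higher number from compound 1 to compound 3 (0.82 log units; beyond the scatter) and thus sets both pyridinyl compounds apart from compound 1, which has the lowest number of the three. Nothing available on these compounds accounts for either step.

The compounds shown leave open whether plain phenyl or 4-methoxyphenyl on the same oxygen would stay with compound 1 or join compound 2 and compound 3. Also open, from the compounds shown here alone, are what pyridin-3-yl would give and what an amine in place of that oxygen would do to the number in this assay here.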